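Two sulfonates at the assay limit, and a third

A few compounds are considered here, and "the series" means these few. Any claim that something is new, unique, unknown or untested is made for them only; others in the source may bear on it.

Measured compounds:
- compound 1 `CCCCN1CCN(c2ccc(S(=O)(=O)Oc3ccccc3)cc2)C1=O` reads > 100000 nM as a limit
- compound 2 `CCCCN1CCN(c2ccc(S(=O)(=O)Oc3ccc(F)c(F)c3)cc2)C1=O` reads > 100000 nM as a limit

In a functional assay on M21 cells (Homo sapiens) for antiproliferative activity, read by sulforhodamine B assay, with a stated time of 48 h (on this read-out lower numbers stand for stronger inhibition and higher numbers for weaker inhibition), compound 2 stands at > 100000 nM as a limit of the assay, not a number. Compound 3 `CCCCN1CCN(c2ccc(S(=O)(=O)Oc3cc(Br)cc(Br)c3)cc2)C1=O` differs from it by 3,5-dibromophenyl in place of 3,4-difluorophenyl on an oxygen on the same core. Among the compounds with values here, the one measured step bearing on this is a step that the two limits leave unreadable from compound 1 to compound 2 and gives no size to carry over. Both measured compounds rest at the limit of > 100000 nM in this assay, at which 2 of the 2 values shown sit, so no direction can be read, and a result near that limit is expected. The expected change is an at least 1.2-fold lower number from compound 2 to compound 3 (0.09 log units; that floor lies within the scatter) in this assay with no direction supported by the measured compounds. For compound 3 the estimated value is 80000 nM with an expected range from 15000 nM to 200000 nM.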

Compound 3, half-maximal inhibitory concentration: > 100000 nM
Compound 3 gave a limit, no number; the forecaster's own chance of this, stated with the estimate: 65%; middle value at least 1.2-fold (0.09 log units) away from the limit.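

No step among compound 1, compound 2 and compound 3 can be read, since each rests at a limit of the assay, not a number: the limit of > 100000 nM in this assay, at which 3 of the 3 values shown sit.

The compounds shown leave open whether any group on that oxygen gives a measurable value in this assay at all.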